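A few compounds are considered here, and "the series" means these few. Any claim that something is new, unique, unknown or untested is made for them only; others in the source may bear on it.

Compound 1 `c1cc(-c2cn[nH]c2)c2c(c1)C(c1ncc[nH]1)CC2` — 84%; compound 2 `Cc1ccc2c(c1NS(C)(=O)=O)CCC2c1ncc[nH]1` — 83%; compound 3 `Clc1ccc2c(c1-c1ccn[nH]1)CCC2c1ncc[nH]1` — 40%.

In a functional assay on CHO cells for agonist activity at Alpha-1A adrenergic receptor (Homo sapiens), read by FLIPR and calcium flux (a lower number here means a smaller maximal response, a higher number a larger maximal response), compound 1 gives 84%, the top of the three numbers; compound 2 gives 83%, within the scatter of that, while compound 3 gives 40%, beyond the scatter below it. Compound 4 `c1cncc(-c2cccc3c2CCC3c2ncc[nH]2)c1` has not been measured. It differs from compound 1 in one place: pyridin-3-yl in place of 1H-pyrazol-4-yl on an aromatic carbon. For the measured compounds named here, no measured pair isolates this change, and compound 3 differs from compound 1 in more than one place, so its value says little about this swap. A modest downward step is expected, a number 14 percentage points lower from compound 1 to compound 4 (beyond the scatter), with a wide range on either side. Compound 4 is estimated at 70%, between 40% and 95%.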

Compound 4, largest response reached (Emax), in percent of the reference or control that the assay uses: 36%
The estimate for compound 4 lay 34 percentage points above the measured number; the whole stated range lies above it.
By their numbers in this assay, from the lowest: compounds 4 and 3 (each within the scatter of the next); then compounds 2 and 1 (each within the scatter of the next).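

In this assay, putting pyridin-3-yl in place of 1H-pyrazol-4-yl on this aromatic carbon gives a number 48 percentage points lower from compound 1 to compound 4 (beyond the scatter), the first step measured at this position, so the maximal response here clearly depends on which aromatic ring the carbon carries. The change alters the ring size, the heavy-atom count and the hydrogen-bond donor count together, so this one step cannot separate them. No available evidence bears on why the response falls.

The compounds shown leave open whether a plain phenyl ring, a pyrimidin-5-yl ring or a primary amide on this carbon would keep the response of compound 1.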